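The source may hold more compounds than are shown below. What is called first, only, known or untested is meant among the compounds shown, and "the series" means these compounds.

In a functional assay on CCRF-CEM cells (Homo sapiens) for antiproliferative activity, read by cell counting, with a stated time of 2 days (on this read-out lower numbers stand for stronger inhibition and higher numbers for weaker inhibition), compound 1 (`COc1ccc(Nc2nc(N)c(C(=O)c3ccccc3)s2)cc1`) gives 300 nM and compound 2 (`COc1ccc(Nc2nc(N)c(C(=O)c3ccc(Cl)cc3)s2)cc1`) gives 19 nM. Compound 3 (`COc1ccc(C(=O)c2sc(Nc3ccc(Cl)cc3)nc2N)cc1`) is recorded only as a limit, > 10000 nM, and not as a number. This is the limit of > 10000 nM in this assay, at which 1 of the 3 values shown sits.

Compound 4 (`Nc1nc(Nc2ccc(Cl)cc2)sc1C(=O)c1ccccc1`) departs from compound 3 by a single change: hydrogen in place of methoxy on an aromatic carbon. In words, hydrogen stands in place of methoxy on an aromatic carbon, taking 4-methoxyphenyl to phenyl.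

Among the measured compounds shown here, one measured step bears on this change, and only loosely: a 16-fold lower number from compound 1 to compound 2 (1.20 log units; beyond the scatter). It is large and beyond the scatter, and it shows that replacing one substituent on an aromatic carbon can shift the number strongly within this series. However, it introduces chloro in place of hydrogen, and no measured step removes methoxy. Its size therefore cannot be carried over directly, and its direction gives no firm guide.

On these data alone, with compound 3 known only as a limit, the starting point of the step is also open. A moderate move towards a lower number is expected, although a second reading at the limit remains quite possible. The expected change is an at least 2.5-fold lower number from compound 3 to compound 4 (0.39 log units; beyond the scatter). For compound 4 the estimate is 4000 nM, with an expected range of 600 nM to 10000 nM.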

Compound 4, half-maximal inhibitory concentration: > 10000 nM
Compound 4: only a limit was reported (the forecaster's own chance of this, stated with the estimate: 45%); middle value at least 2.5-fold (0.39 log units) from the limit.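

Removing methoxy from compound 3 does not bring the series off the limit in this assay: compound 4 is also recorded only as a limit, so the step between them cannot be read. The readable step is an at least 33-fold higher number from compound 1 to compound 4 (1.52 log units; beyond the scatter), for chloro in place of methoxy on an aromatic carbon, and it runs opposite to a 16-fold lower number from compound 1 to compound 2 (1.20 log units; beyond the scatter), where chloro replaced hydrogen on the other aromatic ring. Chloro is therefore not favourable at every aromatic carbon in this series, and the absence of methoxy from the ring bearing the ketone does not by itself give a measurable number when chloro stays on the other ring: the limit of > 10000 nM in this assay, at which 2 of the 4 values shown sit.

On these data alone, how far compound 3 and compound 4 lie beyond the limit remains unknown, so no size or direction can be given to the loss of methoxy in this setting. As far as these compounds go, whether an amine, a hydroxyl group or fluoro in place of chloro on that ring would bring the number back towards compound 1 (300 nM) also remains open.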